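From dimethylamino to azetidin-1-yl on a carbonyl carbon

The compounds below may be only part of what the source reports. "The series", "measured", "known", "first", "only" and "open" are said of these compounds alone.

In a physicochemical assay for lipophilicity (on this read-out lower numbers stand for lower lipophilicity and higher numbers for higher lipophilicity), compound 1 `C[C@@H](CO)Oc1cc(Oc2ccc(C(=O)N(C)C)cc2)cc(C(=O)Nc2ccn(C)n2)c1` reads 1.7 and compound 2 `COC[C@H](C)Oc1cc(Oc2ccc(C(=O)N(C)C)cc2)cc(C(=O)Nc2cc[nH]n2)c1` reads 1.8 on the same scale, so the two lie within the scatter of each other. Among the measured compounds shown here, they differ in more than one place, and no measured pair isolates a single change. Compound 3 `C[C@@H](CO)Oc1cc(Oc2ccc(C(=O)N3CCC3)cc2)cc(C(=O)Nc2ccn(C)n2)c1` keeps the core of compound 1 and carries azetidin-1-yl in place of dimethylamino on a carbonyl carbon. For the measured compounds named here, no measured step covers this exchange, so the expectation rests on the structural change and on compound 1 at 1.7 as the starting point. The expected change is small, slightly upward if anything and not clearly beyond the scatter, an estimated step (a number 0.10 log units higher from compound 1 to compound 3 (within the scatter)). In this assay compound 3 is estimated at 1.8 with an expected range (1.5 to 2.1).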

Compound 3, distribution coefficient: 1.8
Estimate against measurement, compound 3: no gap at the digits printed, within the range that was stated.
By their numbers in this assay, from the lowest: compounds 1, 2 and 3 (each within the scatter of the next).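

In this assay, azetidin-1-yl in place of dimethylamino on a carbonyl carbon gives the only single-place step among these compounds (a number 0.10 log units higher from compound 1 to compound 3 (within the scatter)). The four-membered non-aromatic ring therefore enters at this position without separating compound 3 from compound 1 on this read-out, so this carbonyl carbon accepts the exchange with no change beyond the scatter. Nothing at hand bears on why the step has this size.

The compounds shown leave open whether a larger ring on the same carbonyl carbon, such as pyrrolidin-1-yl or morpholin-4-yl, would also stay within the scatter of compound 1. They also leave open whether the same exchange would give a step of this size on the core of compound 2, and this single step describes only the core of compound 1.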